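This account rests on a few compounds, and the source may have more. Where it says the series, first, only, none or still open, it means among the compounds named here.

Measured so far:
Compound 1 `Oc1cccc(C(c2c[nH]c3ccc(Br)cc23)c2c[nH]c3ccc(Br)cc23)c1`: 3900 nM
Compound 2 `COc1ccc(C(c2c[nH]c3ccc(Br)cc23)c2c[nH]c3ccc(Br)cc23)cc1`: 5500 nM
Compound 3 `Brc1ccc2[nH]cc(C(c3c[nH]c4ccc(Br)cc34)C3CCCCC3)c2c1`: 3200 nM

In a functional assay on HeLa cells (Homo sapiens) for inhibition, read by MTT assay, with a stated time of 48 h (on this read-out lower numbers stand for stronger inhibition and higher numbers for weaker inhibition), compound 3 gives 3200 nM. On these numbers it cannot be separated from the other two compounds. The measured steps are a 1.2-fold lower number from compound 1 to compound 3 (0.09 log units; within the scatter) and a 1.7-fold lower number from compound 2 to compound 3 (0.24 log units; within the scatter).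

The next compound to be tested is compound 4 `CCCCCCCC(c1c[nH]c2ccc(Br)cc12)c1c[nH]c2ccc(Br)cc12`. It keeps the shared core and differs from compound 3 in one group: heptyl in place of cyclohexyl on a saturated chain carbon bound to two aromatic carbons.

All three measured steps change this same place. The third, a 1.4-fold higher number from compound 1 to compound 2 (0.15 log units; within the scatter), is also small. So three different groups here have given values that the scatter cannot tell apart. None of them is an open chain, however, so the expectation for heptyl is an extrapolation and its range should stay wide.

No step beyond the scatter is expected in this assay. The expected step is a 1.1-fold higher number from compound 3 to compound 4 (0.05 log units; within the scatter). For compound 4 the estimated value is 3600 nM, with an expected range from 1500 nM to 8500 nM.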

Compound 4, half-maximal inhibitory concentration: 1300 nM
The estimate for compound 4 lay 2.8-fold (0.44 log units) above the measured number, outside the stated range (below it).
By their numbers in this assay, from the lowest: compound 4; then compounds 3, 1 and 2 (each within the scatter of the next).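

Going by these compounds alone, until this result, the cyclohexyl, 3-hydroxyphenyl and 4-methoxyphenyl groups could not be told apart, and the position on the saturated chain carbon bound to two aromatic carbons seemed not to respond to the group it carried. Heptyl changes that picture in this assay, giving steps beyond the scatter against all three compounds: a 2.5-fold lower number from compound 3 to compound 4 (0.39 log units; beyond the scatter) and a 3.0-fold lower number from compound 1 to compound 4 (0.48 log units; beyond the scatter) and also a 4.2-fold lower number from compound 2 to compound 4 (0.63 log units; beyond the scatter). The closest comparison is with cyclohexyl, where one change removes the ring and also moves from 6 heavy atoms to 7, so the position can distinguish between groups of similar carbon count, though nothing available explains the difference.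

As far as these compounds go, this single step cannot separate the effect of having an open chain from the effect of having one more carbon, and so it remains unknown which of the two matters. From the compounds shown here alone, a shorter butyl chain, a longer decyl chain, and a heptyl chain ending in an amine would each test a different part of this question, and how far the lower numbers extend along such a series remains open.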